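Replacing 2-(4-methoxyphenyl)ethenyl in compound 2

This account rests on a few compounds, and the source may have more. Where it says the series, first, only, none or still open, it means among the compounds named here.

In an ADME assay on HepG2 2.2.15 cells (Homo sapiens) for cytotoxicity (on this read-out higher numbers stand for lower toxicity in this test and lower numbers for higher toxicity in this test), compound 2 `COc1ccc(/C=C/C(=O)OCCc2c(-c3ccccc3Cl)c3cc(Cl)ccc3[nH]c2=O)cc1` gives > 1200000 nM, which is a limit and not a number. Compound 3 `C/C=C(\C)C(=O)OCCc1c(-c2ccccc2Cl)c2cc(Cl)ccc2[nH]c1=O` carries 1-methylprop-1-en-1-yl in place of 2-(4-methoxyphenyl)ethenyl on a carbonyl carbon. In this assay, compound 1 `CC(=O)OCCc1c(-c2ccccc2Cl)c2cc(Cl)ccc2[nH]c1=O` gives 27000 nM. For the measured compounds named here, the only measured step bearing on this change is the large at least 44-fold higher number from compound 1 to compound 2 (1.64 log units; beyond the scatter), which replaces methyl with 2-(4-methoxyphenyl)ethenyl. Part of that step is expected to be lost, with a lower number in this assay. The expected size is an at least 12-fold lower number from compound 2 to compound 3 (1.07 log units; beyond the scatter). Compound 3 is estimated at 100000 nM, with an expected range of 25000 nM to 500000 nM.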

Compound 3, half-maximal cytotoxic concentration: 350000 nM
Estimate against measurement, compound 3: 3.5-fold (0.54 log units) below; the measured number falls inside the stated range.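

On the carbonyl carbon, 1-methylprop-1-en-1-yl also gives a number well clear of methyl, with a 13-fold higher number from compound 1 to compound 3 (1.11 log units; beyond the scatter) in this assay, so the rise is not confined to 2-(4-methoxyphenyl)ethenyl. Going by these compounds, the smaller group still falls short of the larger one, with an at least 3.4-fold lower number from compound 2 to compound 3 (0.53 log units; beyond the scatter), and the true size of that gap stays open. Compound 2 stands at a limit and not a number: the limit of > 1200000 nM in this assay, at which 1 of the 3 values shown sits.

Both replacements for methyl carry a double bond outside aromatic rings. On these data alone, whether the rise needs that double bond stays open, and a saturated longer chain on this carbonyl carbon would bear on it.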